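Aryl Carbonyl Exchange: From Compound 2 to Compound 3

The source may report more compounds than this note shows. Statements on the series, on what has been measured and on what is new or still open speak of the compounds shown alone.

Measured so far in a functional assay on MKN-74 cells (Homo sapiens) for antiproliferative activity, with a stated time of 24 h; on this read-out higher numbers stand for weaker inhibition and lower numbers for stronger inhibition:
compound 1, `NC(=O)c1c(NC(=O)c2ccccc2Cl)sc2c1CCN(C(=S)Nc1ccccc1C(F)(F)F)C2`, gives 1870 nM
compound 2, `NC(=O)c1c(NC(=O)c2ccccc2I)sc2c1CCN(C(=S)Nc1ccccc1Cl)C2`, gives 17500 nM

Compound 2 holds the higher of the two numbers, and its gap to compound 1 lies beyond the scatter; compound 1 differs from it in two places, so that gap cannot be tied to one change. Compound 3, `NC(=O)c1c(NC(=O)c2cccc([N+](=O)[O-])c2)sc2c1CCN(C(=S)Nc1ccccc1Cl)C2`, is not yet measured. It differs from compound 2 by 3-nitrophenyl in place of 2-iodophenyl on a carbonyl carbon. Going by the values given here, no measured pair isolates this change, so the step is expected to be small: a 1.3-fold lower number from compound 2 to compound 3 (0.13 log units; within the scatter), within the scatter. Compound 3 is accordingly estimated at 13000 nM, in a range from 3000 nM to 50000 nM.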

Compound 3, half-maximal inhibitory concentration: 8850 nM
For compound 3 the middle estimate is 1.5-fold (0.17 log units) above the measured one; the range from low to high includes it.
By their numbers in this assay, from the lowest: compound 1; then compounds 3 and 2 (each within the scatter of the next).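

In this assay, going by these compounds alone, the exchange on this carbonyl carbon gives a 2.0-fold lower number from compound 2 to compound 3 (0.30 log units; within the scatter), so this is the first single-place change, and it leaves the two compounds within the scatter of each other. At this position, 3-nitrophenyl and 2-iodophenyl are therefore not told apart by this read-out, even though the two groups differ in their substituent and its place on the ring. No measurement offered here explains this result.

From the compounds shown here alone, whether an aminophenyl or a carboxylic acid on this carbonyl carbon would read the same remains open. Also open, going by these compounds, is which of the two places separating compound 1 from compound 2 carries the gap between them.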